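From Phenyl to Benzyl: A Small Step in Mice

This account rests on a few compounds, and the source may have more. Where it says the series, first, only, none or still open, it means among the compounds named here.

- Compound 1 `CNC(=O)[C@@H](C)NCc1ccc(OCc2ccccc2)cc1` gives 7 mg/kg
- Compound 2 `C[C@@H](NCc1ccc(Cc2ccccc2)cc1)C(N)=O` gives 22.5 mg/kg

Among the measured compounds shown here, only two compounds have been measured so far, both in a functional assay on the whole organism with Mus musculus as the target, in the maximal electroshock model; a lower number here means that less compound is needed, a higher number that more compound is needed for the effect. Of the two numbers, compound 2 has the higher one at 22.5 mg/kg, and compound 1 lies lower at 7 mg/kg, a gap beyond the usual scatter of repeated measurements.

Compound 3 `C[C@@H](NCc1ccc(CCc2ccccc2)cc1)C(N)=O` is compound 2 with a single change (benzyl in place of phenyl on a saturated chain carbon bound to an aromatic carbon): benzyl in place of phenyl on a saturated chain carbon bound to an aromatic carbon.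

For the measured compounds named here, no measured pair differs in just one place, so the data show nothing directly about what such a change does. The lower number of compound 1 at 7 mg/kg is only a weak hint of a downward direction, since compound 1 differs from compound 2 in more than one place. In this assay, a small drop that stays within the scatter is therefore expected, and the estimated step is a 1.5-fold lower number from compound 2 to compound 3 (0.18 log units; within the scatter). For compound 3 the estimated dose is 15 mg/kg, with an expected range from 6 mg/kg to 40 mg/kg.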

Compound 3, dose for half-maximal effect: 17.8 mg/kg
For compound 3 the middle estimate is 1.2-fold (0.07 log units) below the measured one, within the range that was stated.
By their numbers in this assay, from the lowest: compound 1; then compounds 3 and 2 (each within the scatter of the next).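

Among the compounds shown here, this is the first pair of measured compounds that differ in just one place, so the effect of this change can now be read directly: in this assay, benzyl in place of phenyl on a saturated chain carbon bound to an aromatic carbon gives a 1.3-fold lower number from compound 2 to compound 3 (0.10 log units; within the scatter). Repeated measurements of one compound could differ by as much, so the two compounds cannot be told apart in this assay, and this one change shows no effect on the dose needed. At this position, then, the data support only the modest statement that swapping phenyl for benzyl leaves the result within the usual scatter. Nothing available explains this outcome, and no further measurement bears on it.

A single step cannot show how far this tolerance extends: a longer chain ending in phenyl, or an amine or a carboxylic acid at the same place, could behave quite differently. Compound 1 differs from both compound 2 and compound 3 in more than one place, so its lower value cannot be assigned to any single change, and the steps linking it to them cannot be read.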